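Methoxy for methyl on a Vero cell cytotoxicity series

The source may hold more compounds than are shown below. What is called first, only, known or untested is meant among the compounds shown, and "the series" means these compounds.

Two compounds that share a core have been examined for cytotoxicity. Compound 1 `Clc1ccc2c(NCCNc3nccc(Nc4ccc(Br)cc4)n3)ccnc2c1` carries a bromine on its outer phenyl ring and, in an ADME assay on Vero cells (Chlorocebus sabaeus) for cytotoxicity, read by neutral red uptake, with a stated time of 72 h (on this read-out higher numbers stand for weaker inhibition and lower numbers for stronger inhibition), compound 1 was reported as "not active" (no number reported), without a number. Compound 2 `Cc1ccc(Nc2ccnc(NCCNc3ccnc4cc(Cl)ccc34)n2)cc1` carries a methyl at the same position, and in this assay compound 2 gives 13600 nM. Within the data shown here, compound 2 therefore stands alone as the only numbered value in this assay; the report for compound 1 cannot be set beside it on a scale.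

Compound 3 `COc1ccc(Nc2ccnc(NCCNc3ccnc4cc(Cl)ccc34)n2)cc1` differs from compound 2 in one place: methoxy in place of methyl on an aromatic carbon. Among the measured compounds shown here, no measured pair shows the effect of this exchange in this assay, so the expectation must rest on the single value of compound 2 and on the modest nature of the change. The step from compound 2 to compound 3 is expected to be small, a 1.1-fold higher number from compound 2 to compound 3 (0.04 log units; within the scatter), with no direction that clearly rises above the scatter of repeated measurements. For compound 3 the estimated value in this assay is 15000 nM, within a range of 6000 nM to 40000 nM.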

Compound 3, half-maximal inhibitory concentration: "not active" (no number reported)
Compound 3 has no reported number here, and the estimate cannot be compared.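

In this assay, among these compounds, compound 3 was reported without a number, so no step from compound 2 to compound 3 can be read. Nothing shown here bears on the reason for this result. The compounds shown leave open how the exchange of methyl for methoxy shifts the read-out, and where compound 1 and compound 3 stand relative to compound 2.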